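A Furan in Place of a Tolyl Group

The compounds below may be only part of what the source reports. "The series", "measured", "known", "first", "only" and "open" are said of these compounds alone.

Three compounds have been measured in a functional assay on Ehrlich cells (Mus musculus) for cytotoxicity, tested at 10 ug/mL; on this read-out lower numbers stand for a weaker effect and higher numbers for a stronger effect at the one concentration tested:
compound 1 `COc1ccc(C2C(C#N)=C(N)N(c3cc(OC)c(OC)c(OC)c3)C3=C2C(=O)CC(C)(C)C3)cc1`: 0%
compound 2 `COc1cc(N2C(N)=C(C#N)C(/C=C/c3ccccc3)C3=C2CC(C)(C)CC3=O)cc(OC)c1OC`: 10%
compound 3 `COc1cc(N2C(N)=C(C#N)C(c3ccc(C)cc3)C3=C2CC(C)(C)CC3=O)cc(OC)c1OC`: 30%

Compound 3 stands highest of the three in this assay; compound 2 is nearest, and the step of a number 20 percentage points higher from compound 2 to compound 3 (beyond the scatter) is beyond the scatter, as is the larger step of a number 30 percentage points higher from compound 1 to compound 3 (beyond the scatter). The step of a number 10 percentage points higher from compound 1 to compound 2 (within the scatter) lies within the scatter.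

Compound 4 `COc1cc(N2C(N)=C(C#N)C(c3ccc(C)o3)C3=C2CC(C)(C)CC3=O)cc(OC)c1OC` differs from compound 3 only at the group on the saturated ring carbon: 5-methylfuran-2-yl in place of 4-methylphenyl on a saturated ring carbon. The two steps that bear on this position both end at compound 3 and both raised the read-out, a number 20 percentage points higher from compound 2 to compound 3 (beyond the scatter) and a number 30 percentage points higher from compound 1 to compound 3 (beyond the scatter). Among the measured compounds shown here, no measured step replaces the 4-methylphenyl with a five-membered aromatic ring, so the direction for compound 4 is uncertain. Both neighbouring changes at this site moved the number by a modest amount, so a step of similar size, more likely downward, is expected for compound 4 in this assay, as a number 10 percentage points lower from compound 3 to compound 4 (within the scatter). Compound 4 is therefore estimated at 20%, within 0% to 45%.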

Compound 4, a percentage reported as activity, at one concentration (the size of the read-out at that concentration, not a potency): 21%
For compound 4 the middle estimate is 1 percentage points below the measured one; low and high end bracket the measured number.
By their numbers in this assay, from the lowest: compounds 1 and 2 (each within the scatter of the next); then compounds 4 and 3 (each within the scatter of the next).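

In this assay the first five-membered aromatic ring at this saturated ring carbon, 5-methylfuran-2-yl, cannot be told apart from 4-methylphenyl, with a number 9 percentage points lower from compound 3 to compound 4 (within the scatter) and thus no readable effect of exchanging the carbon-only six-membered ring for a ring with one hetero atom. The furan still stands clear of the two other groups at this carbon, with a number 11 percentage points higher from compound 2 to compound 4 (beyond the scatter) and with a number 21 percentage points higher from compound 1 to compound 4 (beyond the scatter) so that compound 3 and compound 4 form a pair above compound 1 and compound 2. No information is available to explain these readings.

It remains open whether the methyl on either ring matters, since a plain furan-2-yl or phenyl group does not appear among these compounds. From the compounds shown here alone, it is also open how a thiophene, a pyridine or an aminophenyl group would read at this carbon.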